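Moving a methyl group on the sulfonamide aryl of compound 3

This account rests on a few compounds, and the source may have more. Where it says the series, first, only, none or still open, it means among the compounds named here.

In an assay on isolated protein for inhibition of Nicotinamide phosphoribosyltransferase (Homo sapiens), read by WST assay, with stated times of 60 min, 5 min and 30 min, in the presence of a further agent that is not named here (a lower number here means a stronger inhibitor, a higher number a weaker inhibitor), compound 1 `O=C(/C=C/c1cccnc1)NCCCCCCCc1ccc(S(=O)(=O)Nc2ccccc2)cc1` gives 16.4 nM, compound 2 `O=C(/C=C/c1cccnc1)NCCCCCCc1cccc(S(=O)(=O)Nc2ccccc2)c1` gives 10.5 nM, and compound 3 `Cc1ccc(NS(=O)(=O)c2cccc(CCCCCCNC(=O)/C=C/c3cccnc3)c2)cc1` gives 9.78 nM. Compound 3 shows the lowest of the three numbers, but its gaps to compound 2 and to compound 1 both sit within the scatter, so the three compounds cannot be ranked against each other on these values. For the measured compounds named here, the one single-point step measured so far, a 1.1-fold lower number from compound 2 to compound 3 (0.03 log units; within the scatter), shows that adding a methyl group barely moved the number.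

Compound 4 `Cc1ccccc1NS(=O)(=O)c1cccc(CCCCCCNC(=O)/C=C/c2cccnc2)c1` differs from compound 3 by 2-methylphenyl in place of 4-methylphenyl on a sulfonamide nitrogen. Going by the values given here, no measured step shows what moving a methyl group from one position of this ring to another does. Among the compounds with values here, the only related evidence is the step from compound 2 to compound 3, where the methyl group itself made no difference beyond the scatter. On that basis the step of a 1.4-fold higher number from compound 3 to compound 4 (0.16 log units; within the scatter) is expected to stay within the scatter as well, with no clear direction. Compound 4 is therefore estimated at 14 nM in this assay, within a range from 6 nM to 40 nM.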

Compound 4, half-maximal inhibitory concentration: 5.08 nM
The estimate for compound 4 lay 2.8-fold (0.44 log units) above the measured number; the whole stated range lies above it.
By their numbers in this assay, from the lowest: compounds 4, 3, 2 and 1 (each within the scatter of the next, the first and the last beyond it).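

Adding a methyl group to the aryl ring on the sulfonamide nitrogen now gives a step that passes the scatter in this assay, although only modestly: a 2.1-fold lower number from compound 2 to compound 4 (0.32 log units; beyond the scatter) is the result for 2-methylphenyl, whereas the earlier step to the 4-methylphenyl compound, a 1.1-fold lower number from compound 2 to compound 3 (0.03 log units; within the scatter) stayed within it. This suggests that a methyl group on this ring can matter, but the evidence is thin: the direct comparison of the two placements, a 1.9-fold lower number from compound 3 to compound 4 (0.28 log units; within the scatter) does not separate 2-methylphenyl from 4-methylphenyl, so the two compounds cannot be ranked against each other. Nothing available here accounts for this result.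

Going by these compounds, it remains open whether a chlorine atom, a methoxy group or a carboxylic acid in place of the methyl group of 2-methylphenyl would lower the number further, leave it unchanged or raise it. Also open, on these data alone, is whether 2-methylphenyl on the sulfonamide nitrogen of compound 1, with its longer chain, would give a step of similar size.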